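A few compounds are considered here, and "the series" means these few. Any claim that something is new, unique, unknown or untested is made for them only; others in the source may bear on it.

Measured in a functional assay on HCT-116 cells (Homo sapiens) for inhibition, read by luminescence and CellTiter-Glo, with a stated time of 72 h; a higher number here means a weaker inhibitor, a lower number a stronger inhibitor:
- compound 1 `Cc1cc2c(NS(C)(=O)=O)cccc2n1-c1nc2c(c(NCc3cccc(O)c3)n1)CCC2`: 800 nM
- compound 2 `C/C=C/C(=O)Nc1cccc2c1cc(C)n2-c1nc2c(c(NCc3cccc(O)c3)n1)CCC2`: 2400 nM
- compound 3 `Cc1cc2c(C(N)=O)cccc2n1-c1nc2c(c(NCc3cccc(O)c3)n1)CCC2`: 400 nM

Of these three, compound 2 has the highest number, at 2400 nM, and its steps to both others lie beyond the scatter. Compound 4 `CCONC(=O)c1cccc2c1cc(C)n2-c1nc2c(c(NCc3cccc(O)c3)n1)CCC2` is the next to be tested in this assay. It has ethoxycarbamoyl in place of ((prop-1-en-1-yl)carbonyl)amino on an aromatic carbon.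

The closest evidence is the step that removes the same group in favour of carbamoyl, a 6.0-fold lower number from compound 2 to compound 3 (0.78 log units; beyond the scatter). The step of a 3.0-fold higher number from compound 1 to compound 2 (0.48 log units; beyond the scatter) also shows that this group gives a higher number than methanesulfonamido does. Against that, a 2.0-fold lower number from compound 1 to compound 3 (0.30 log units; within the scatter) shows that the other two groups are not clearly separated. Within the data shown here, no measured compound carries ethoxycarbamoyl, so what the ethoxy part adds to carbamoyl is unknown, and only part of the gain seen with compound 3 at 400 nM is assumed to carry over.

A modest move to a lower number is therefore expected, and the estimated step is a 2.7-fold lower number from compound 2 to compound 4 (0.43 log units; beyond the scatter). For compound 4 the estimate is 900 nM, with an expected range from 300 nM to 2700 nM.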

Compound 4, half-maximal inhibitory concentration: 600 nM
Compound 4: the middle estimate sits 1.5-fold (0.18 log units) above what was measured; the measured number falls inside the stated range.
By their numbers in this assay, from the lowest: compounds 3, 4 and 1 (each within the scatter of the next); then compound 2.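

In this assay, among these compounds, the step of a 1.5-fold higher number from compound 3 to compound 4 (0.18 log units; within the scatter) shows that ethoxy can stand in place of hydrogen on the amide-type nitrogen of the group on this aromatic carbon without a shift beyond the scatter, something the earlier compounds could not show, as none of them carried a substituent on that nitrogen. The step of a 4.0-fold lower number from compound 2 to compound 4 (0.60 log units; beyond the scatter) adds a second replacement for ((prop-1-en-1-yl)carbonyl)amino that lies beyond the scatter, while a 1.3-fold lower number from compound 1 to compound 4 (0.12 log units; within the scatter) leaves ethoxycarbamoyl and methanesulfonamido unseparated, so that among these four compounds only compound 2 stands apart. Nothing among the data given explains why the numbers fall as they do at this position.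

As far as these compounds go, it remains open whether a shorter methoxy group or a longer propoxy chain on the same nitrogen would also leave the number within the scatter of compound 3. Also open, from the compounds shown here alone, is how a carboxylic acid or a primary amine on this aromatic carbon would compare with carbamoyl and ethoxycarbamoyl, and whether any such group would give a number clearly separated from those of compound 1, compound 3 and compound 4.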